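Moving the trifluoromethyl group on the acyl ring

The source may report more compounds than this note shows. Statements on the series, on what has been measured and on what is new or still open speak of the compounds shown alone.

Compound 1 `CN(C(=O)NC(=O)c1cccc(C(F)(F)F)c1)c1nc(C(F)(F)F)c(C(=O)N/N=C/c2cccc(C(F)(F)F)c2)s1` is tested in a functional assay on BCG823 cells (Homo sapiens) for inhibition, read by MTT assay, with a stated time of 72 h (on this read-out lower numbers stand for stronger inhibition and higher numbers for weaker inhibition), and gives 4.6 ug/mL, the lowest of the two numbers recorded. Compound 2 `CN(C(=O)NC(=O)c1cccc(C(F)(F)F)c1)c1nc(C(F)(F)F)c(C(=O)N/N=C/c2ccccc2C(F)(F)F)s1` gives 7.29 ug/mL in this assay, and the change a 1.6-fold higher number from compound 1 to compound 2 (0.20 log units; within the scatter) is within the scatter. Compound 3 `CNc1nc(C(F)(F)F)c(C(=O)N/N=C/c2ccccc2C(F)(F)F)s1`, which lacks the acylurea arm, gives > 100 ug/mL in this assay, a limit of the assay rather than a number, namely (the limit of > 100 ug/mL in this assay, at which 1 of the 3 values shown sits). The unmeasured compound 4 `CN(C(=O)NC(=O)c1ccc(C(F)(F)F)cc1)c1nc(C(F)(F)F)c(C(=O)N/N=C/c2cccc(C(F)(F)F)c2)s1` differs from compound 1 by 4-(trifluoromethyl)phenyl in place of 3-(trifluoromethyl)phenyl on a carbonyl carbon. Within the data shown here, the one measured step that bears on it, the shift of the same group on the other ring from compound 1 to compound 2, stayed within the scatter, so no step beyond the scatter is expected here either, in either direction. Compound 4 is therefore estimated at 5.5 ug/mL, between 2.2 ug/mL and 14 ug/mL, a step of a 1.2-fold higher number from compound 1 to compound 4 (0.08 log units; within the scatter).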

Compound 4, half-maximal inhibitory concentration: 1.84 ug/mL
Beside the measured number, compound 4's estimate is 3.0-fold (0.48 log units) above it; the measured number lies below the stated range.
By their numbers in this assay, from the lowest: compound 4; then compounds 1 and 2 (each within the scatter of the next). At a limit, above all of these: compound 3.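

In this assay, 4-(trifluoromethyl)phenyl in place of 3-(trifluoromethyl)phenyl on a carbonyl carbon gives a 2.5-fold lower number from compound 1 to compound 4 (0.40 log units; beyond the scatter), a modest step. Of the two shifts of this group shown, only this one lies beyond the scatter, so the position of the trifluoromethyl group on this ring affects the number, whereas the other shift, a 1.6-fold higher number from compound 1 to compound 2 (0.20 log units; within the scatter), does not separate its compounds. Nothing shown explains why this shift lowers the number.

Still open, as far as these compounds go, is whether 2-(trifluoromethyl)phenyl on the same carbonyl carbon would lower the number further. Also open, from the compounds shown here alone, is whether a phenyl ring carrying a carboxylic acid or an amine in place of trifluoromethyl would keep this gain.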